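The source may hold more compounds than are shown below. What is called first, only, known or untested is meant among the compounds shown, and "the series" means these compounds.

Among the three compounds with numbers, compound 2 `CC(C)=CCC1Cc2c(OC(=O)Nc3ccc(F)cc3)cc(=O)n(CCCO)c2CC1(C)C` stands highest in a functional assay on PANC-1 cells (Homo sapiens) for inhibition, read by MTT assay, with a stated time of 24 h, tested at 10 uM; a higher number here means more inhibition at the concentration tested (going by the name of the read-out), a lower number less inhibition: compound 2 gives 71.2%. Compound 1 `CC(C)=CCC1Cc2c(OCCCOc3ccc(Cl)cc3)cc(=O)n(CCCO)c2CC1(C)C` gives 22.7%, and the change a number 48.5 percentage points higher from compound 1 to compound 2 (beyond the scatter) turns on the group held by the ring oxygen. Compound 3 `CC(C)=CCC1Cc2c(OC(=O)Nc3cccc(C(F)(F)F)c3)cc(=O)n(CCCO)c2CC1(C)C` gives 54.3%, the change being a number 16.9 percentage points lower from compound 2 to compound 3 (beyond the scatter), again at the carbamate end.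

Compound 4 `CC(C)=CCC/C(C)=C/CC1Cc2c(OC(=O)Nc3ccc(F)cc3)cc(=O)n(CCCO)c2CC1(C)C` differs from compound 2 elsewhere: 3-methylbut-2-en-1-yl in place of hydrogen on a saturated chain carbon bound to a double-bonded chain carbon. Cut one bond further out, the change reads 3-methylbut-2-en-1-yl to 3,7-dimethylocta-2,6-dien-1-yl, a lengthening of the unsaturated chain on the core, far from the carbamate where both measured steps fell. For the measured compounds named here, neither step speaks to this position, so there is no measured precedent for it here. Compound 4 is therefore expected to stay close to compound 2, with the step of a number 6.2 percentage points lower from compound 2 to compound 4 (within the scatter) estimated to lie within the scatter. The expected value for compound 4 is 65%, in a range from 45% to 82%.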

Compound 4, a percentage reported as inhibition, at one concentration (the size of the read-out at that concentration, not a potency): 43.9%
For compound 4 the middle estimate is 21.1 percentage points above the measured one, outside the stated range (below it).
By their numbers in this assay, from the lowest: compound 1; then compound 4; then compound 3; then compound 2.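

The unsaturated chain on the core, held fixed in compounds 1 to 3, turns out to count in this assay: with the 4-fluorophenyl carbamate unchanged, 3,7-dimethylocta-2,6-dien-1-yl in place of 3-methylbut-2-en-1-yl gives a number 27.3 percentage points lower from compound 2 to compound 4 (beyond the scatter) and so lies beyond the scatter. The carbamate end is therefore not the only place where this read-out moves, and in this single pair the added 3-methylbut-2-en-1-yl unit lowers the number rather than raising it. No measurement at hand accounts for this fall.

For the compounds shown here, with only this pair at the position, it remains open how a shorter group such as methyl, or a saturated chain such as decyl, would compare with compound 2. On these data alone, it is also open whether the same lengthening lowers the number when the carbamate carries the 3-(trifluoromethyl)phenyl group of compound 3.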